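From fluoro to methylsulfanyl in a cytotoxicity series

The source may hold more compounds than are shown below. What is called first, only, known or untested is meant among the compounds shown, and "the series" means these compounds.

Values in an ADME assay on WI-38 cells (Homo sapiens) for cytotoxicity, read by MTT assay, with a stated time of 72 h; a lower number here means a stronger inhibitor, a higher number a weaker inhibitor:
- Compound 1 `CC(C)(C)NC(=O)CCc1cccc2c1B(O)OC2`: > 100000 nM, a limit of the assay
- Compound 2 `C#Cc1cccc(NC(=O)CCc2cccc3c2B(O)OC3)c1`: > 100000 nM, a limit of the assay
- Compound 3 `O=C(CCc1cccc2c1B(O)OC2)Nc1cccc(-c2cccc(F)c2)c1`: 37000 nM

The results for compound 1 and compound 2 are limits of the assay. In this assay, going by the values given here, compound 3 holds the only actual number, 37000 nM. Compound 4 `CSc1cccc(-c2cccc(NC(=O)CCc3cccc4c3B(O)OC4)c2)c1` differs from it by one change, methylsulfanyl in place of fluoro on an aromatic carbon. Among the compounds with values here, no measured step alters that fluoro group. The nearest evidence is an at least 2.7-fold lower number from compound 2 to compound 3 (0.43 log units; beyond the scatter), which came with 3-fluorophenyl in place of ethynyl on an aromatic carbon. Compound 4 keeps that phenyl and changes only its substituent, so no step beyond the scatter is expected, and no direction is favoured. The estimated step is a 1.1-fold lower number from compound 3 to compound 4 (0.02 log units; within the scatter). One caution is the limit of > 100000 nM in this assay, at which 2 of the 3 values shown sit. Compound 4 may therefore also return only a limit. The estimate for compound 4 is 35000 nM, with an expected range from 13000 nM to 90000 nM.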

Compound 4, half-maximal inhibitory concentration: 2000 nM
The estimate for compound 4 lay 18-fold (1.24 log units) above the measured number; measured number outside the range, below it.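

In this assay, going by these compounds alone, the group on the outer phenyl ring, which no earlier pair had touched, proves to be a sensitive place: going from 3-fluorophenyl to 3-(methylsulfanyl)phenyl gives a 19-fold lower number from compound 3 to compound 4 (1.27 log units; beyond the scatter). Set against the ethynyl compound, the same outer ring gives an at least 50-fold lower number from compound 2 to compound 4 (1.69 log units; beyond the scatter), so the aryl replacement of ethynyl carries much more weight with methylsulfanyl on it than the fluoro compound alone suggested. Compound 4 also returns an actual number rather than a limit, which leaves two numbers in a set otherwise held at a limit: the limit of > 100000 nM in this assay, at which 2 of the 4 values shown sit.

The compounds shown leave open whether the sulfur matters, since methoxy, methyl or ethylsulfanyl at this carbon would each separate the atom from the size of the group. They also leave open whether methylsulfanyl acts the same way on another carbon of that ring.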